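A few compounds are considered here, and "the series" means these few. Any claim that something is new, unique, unknown or untested is made for them only; others in the source may bear on it.

Working notes on the amine end of the series. In an ADME assay on microsomes from liver (Rattus norvegicus) for metabolic stability, read by LC-MS, using NADPH, at 37 degrees C (on this read-out higher numbers stand for a longer-lived compound and lower numbers for a shorter-lived compound), compound 2 (`Cc1ccccc1-c1nc(CN2CCC(C(=O)NCCCN3CC(C)(C)CC(C)(C)C3)CC2)c(C)o1`) gives 0.095 h, the lowest of the three numbers available. Compound 1 (`Cc1ccc(C)c(-c2nc(CN3CCC(C(=O)NCCCN4C[C@H](C)C[C@H](C)C4)CC3)c(C)o2)c1`) gives 0.5 h and compound 3 (`Cc1oc(-c2ccc(F)cc2)nc1CN1CCC(C(=O)NCCCN2C[C@H](C)C[C@H](C)C2)CC1`) gives 0.468 h, both beyond the scatter from compound 2.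

Compound 4 (`Cc1ccccc1-c1nc(CN2CCC(C(=O)NCCCN3CCCCC3)CC2)c(C)o1`) differs from compound 2 at one place: a group of 6 heavy atoms (5 carbon, 1 nitrogen; one six-membered non-aromatic ring with 1 hetero atom) in place of a group of 10 heavy atoms (9 carbon, 1 nitrogen; one six-membered non-aromatic ring with 1 hetero atom), on a saturated chain carbon, three bonds along the chain from an amide-type nitrogen. Within the data shown here, the only measured step, a 1.1-fold lower number from compound 1 to compound 3 (0.03 log units; within the scatter), lies within the scatter, and it concerns the aromatic substituent, so it bears on this change only indirectly. Among the measured compounds shown here, no measured step covers the group on the saturated chain carbon. Compounds 1 and 3 carry a different group there from compound 2, and the expectation of a rise rests on compound 3 at 0.468 h, though the aromatic substituent differs too. An upward move beyond the scatter is expected, with a 3.2-fold higher number from compound 2 to compound 4 (0.50 log units; beyond the scatter) as the estimated step. Compound 4 is estimated at 0.3 h, with an expected range of 0.1 h to 0.8 h.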

Compound 4, half-life: > 0.5 h
Compound 4: a limit, no number; the forecaster's own chance of this, stated with the estimate: 2%; at least 1.6-fold (0.22 log units) between middle value and limit.
By their numbers in this assay, from the lowest: compound 2; then compounds 3 and 1 (each within the scatter of the next).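

The value for compound 4 in this assay is a limit, not a number: the limit of > 0.5 h in this assay, at which 1 of the 4 values shown sits.

Even so, the change on a saturated chain carbon, three bonds along the chain from an amide-type nitrogen, can now be read directly: piperidin-1-yl in place of the group of 10 heavy atoms gives an at least 5.2-fold higher number from compound 2 to compound 4 (0.72 log units; beyond the scatter). Compounds 1 and 3 differ from compound 2 in the aromatic substituent as well, whereas this step changes that one group alone, with the rest of the molecule held fixed.

As far as these compounds go, how far compound 4 lies past its limit remains open, and with it the full size of the step. Also open, from the compounds shown here alone, is whether a morpholin-4-yl or pyrrolidin-1-yl group at the same place, or a piperidine carrying a single methyl, would keep the half-life at this level.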